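This account rests on a few compounds, and the source may have more. Where it says the series, first, only, none or still open, it means among the compounds named here.

In a functional assay on HOS-TE85 cells (Homo sapiens) for inhibition, read by CCK-8 assay, with a stated time of 72 h (on this read-out lower numbers stand for stronger inhibition and higher numbers for weaker inhibition), three compounds with a shared core have numbers. Compound 1 (`COc1ccc(F)cc1N1C(=O)CSC1c1cccc(C(=O)NCCCCc2ccccc2)c1`) gives 8.8 nM, compound 2 (`CC(F)(F)c1cccc(N2C(=O)CSC2c2cccc(C(=O)NCCCCc3ccccc3)c2)c1`) gives 29.1 nM and compound 3 (`COc1c(F)cccc1N1C(=O)CSC1c1cccc(C(=O)NCCCCc2ccccc2)c1`) gives 26.2 nM. Compound 3 therefore stands with compound 2 and well clear of compound 1, whose number is lower. Compound 4 (`O=C(NCCCCc1ccccc1)c1cccc(C2SCC(=O)N2c2ccc(C3CC3)cc2)c1`) differs from compound 3 in one place: 4-cyclopropylphenyl in place of 3-fluoro-2-methoxyphenyl on an amide-type nitrogen in a ring. Within the data shown here, no measured compound carries a cyclopropyl group, so the closest guides are the other swaps on that same nitrogen. These gave a 3.3-fold higher number from compound 1 to compound 2 (0.52 log units; beyond the scatter), a 3.0-fold higher number from compound 1 to compound 3 (0.47 log units; beyond the scatter) and a 1.1-fold lower number from compound 2 to compound 3 (0.05 log units; within the scatter). Those steps are modest at most, so no step beyond the scatter is expected, and the estimated change is a 1.1-fold higher number from compound 3 to compound 4 (0.06 log units; within the scatter). For compound 4 the expected value is 30 nM, with an estimated range of 10 nM to 90 nM.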

Compound 4, half-maximal inhibitory concentration: 217 nM
Estimate against measurement, compound 4: 7.2-fold (0.86 log units) below; measured number above the stated range.
By their numbers in this assay, from the lowest: compound 1; then compounds 3 and 2 (each within the scatter of the next); then compound 4.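

In this assay, the 4-cyclopropylphenyl group on the amide-type nitrogen gives an 8.3-fold higher number from compound 3 to compound 4 (0.92 log units; beyond the scatter), a 7.5-fold higher number from compound 2 to compound 4 (0.87 log units; beyond the scatter) and a 25-fold higher number from compound 1 to compound 4 (1.39 log units; beyond the scatter), so this position responds more strongly than the earlier swaps suggested. Compound 4 is also the only one of the four whose group on this nitrogen carries no fluorine. Nothing measured here explains the weaker inhibition.

Going by these compounds, the swap changes several features at once, so their separate contributions remain unknown. On these data alone, it also remains open whether a plain phenyl or 4-methoxyphenyl group would give numbers closer to compound 1 or compound 4.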